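A few compounds are considered here, and "the series" means these few. Any claim that something is new, unique, unknown or untested is made for them only; others in the source may bear on it.

In a functional assay on HEL cells (Homo sapiens) for cytotoxicity (a higher number here means that more compound is tolerated, a lower number that less compound is tolerated), compound 1 `O[C@@H]1[C@@H](O)[C@H](c2ccccc2)O[C@@H]2CO[C@@H](c3ccc4ccccc4c3)O[C@@H]12` gives >= 400 ug/mL. In this assay compound 2 `CO[C@@H]1[C@@H](OC)[C@H](c2ccccc2)O[C@@H]2CO[C@@H](Cc3ccccc3)O[C@@H]12` gives "not determined" (no result reported).

The figure for compound 1 in this assay is a limit of the measurement, not a number. Compound 2 has no reported result in this assay, so it stands nowhere on the numbers shown. Of the two entries, one sits at the limit of >= 400 ug/mL in this assay, at which 1 of the 2 values shown sits. Compound 3 `CO[C@@H]1[C@@H](OC)[C@H](c2ccccc2)O[C@@H]2CO[C@@H](c3ccc(C(F)(F)F)cc3)O[C@@H]12` differs from compound 2 by 4-(trifluoromethyl)phenyl in place of benzyl on a saturated ring carbon. Among the compounds with values here, no measured step covers this change in this assay; any step is expected to stay within the scatter. Compound 3 is estimated at 300 ug/mL, between 100 ug/mL and 400 ug/mL.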

Compound 3, minimum cytotoxic concentration: >= 16 ug/mL
Compound 3 gave a limit, no number; the forecaster's own chance of this, stated with the estimate: 60%; the middle value is on the limit's open side.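

Within the data shown here, no step from compound 2 to compound 3 can be read in this assay, as compound 2 has no number. Compound 3 gives >= 16 ug/mL, which is a limit. The compounds shown leave open whether 4-(trifluoromethyl)phenyl in place of benzyl changes the concentration tolerated in this assay.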